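Moving a branch in the side chain of compound 2

This account rests on a few compounds, and the source may have more. Where it says the series, first, only, none or still open, it means among the compounds named here.

Compounds measured in a functional assay on HeLa cells (Homo sapiens) for antiproliferative activity, read by MTT assay, with a stated time of 72 h; a lower number here means a stronger inhibitor, a higher number a weaker inhibitor:
- compound 1 `C=CC(=O)Nc1cccc(Oc2nc(Nc3cccc(C#N)c3)nc3c2CSCC3)c1`: 34900 nM
- compound 2 `CCC/C=C/C(=O)Nc1cccc(Oc2nc(Nc3cccc(C#N)c3)nc3c2CSCC3)c1`: 7220 nM

Of these two, compound 2 has the lower number, at 7220 nM. Compound 3 `CC(C)/C=C/C(=O)Nc1cccc(Oc2nc(Nc3cccc(C#N)c3)nc3c2CSCC3)c1` is not yet measured and differs from it as follows: isopropyl in place of propyl on a double-bonded chain carbon bound to a double-bonded chain carbon. Within the data shown here, only one measured step bears on this change, and it is modest: a 4.8-fold lower number from compound 1 to compound 2 (0.68 log units; beyond the scatter). That step replaced vinyl with a longer chain, whereas here the atoms stay the same and are only joined differently. A much smaller effect in this assay is therefore expected, with no step beyond the scatter and no firm direction. The expected change is a 1.1-fold higher number from compound 2 to compound 3 (0.04 log units; within the scatter). For compound 3 the estimated value is 8000 nM, with an expected range of 3500 nM to 18000 nM.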

Compound 3, half-maximal inhibitory concentration: 22800 nM
Beside the measured number, compound 3's estimate is 2.9-fold (0.45 log units) below it; measured number above the stated range.
By their numbers in this assay, from the lowest: compound 2; then compounds 3 and 1 (each within the scatter of the next).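

In this assay, exchanging propyl for isopropyl gives a 3.2-fold higher number from compound 2 to compound 3 (0.50 log units; beyond the scatter), so with the same atoms, the result at this position depends on how the chain is joined and not only on how many carbons it holds. The branched chain also fails to stand apart from vinyl, with a 1.5-fold lower number from compound 1 to compound 3 (0.18 log units; within the scatter) lying within the scatter. No measurement here explains why the two chains differ. Still open, going by these compounds, is whether a longer straight chain, or a chain carrying an amine, would give a lower number than the propyl-bearing compound 2.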